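Same Amide Chain, Different Amine: Expecting Little

This account rests on a few compounds, and the source may have more. Where it says the series, first, only, none or still open, it means among the compounds named here.

Compound 1 `CC1=NN(C(=O)CCl)C(c2cc(Br)ccc2O)C1` gives 16300 nM in a functional assay on HepG2 cells (Homo sapiens) for cytotoxicity, read by MTT assay, with a stated time of 48 h; a lower number here means a stronger inhibitor, a higher number a weaker inhibitor.
Compound 2 `O=C(CNC1CC1)N1N=C(c2cc3ccccc3oc2=O)CC1c1ccccc1` is reported in this assay as "not active" (no number reported), with no number.

These two compounds share nothing beyond the assay, so only their separate results can be stated: compound 1 returns a measurable number, while compound 2 returns no number at all. Compound 2 therefore stands nowhere on the scale; it is simply the compound for which this assay reports no activity.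

Compound 3 `O=C(CN1CCC(O)CC1)N1N=C(c2cc3ccccc3oc2=O)CC1c1ccccc1` keeps the whole core of compound 2 and changes only the group attached to the carbonyl-bound chain carbon: 4-hydroxypiperidin-1-yl in place of cyclopropylamino on a saturated chain carbon bound to a carbonyl carbon. A 4-hydroxypiperidin-1-yl group replaces the cyclopropylamino group there, and the rest of the molecule is unchanged.

Going by the values given here, with no measured step anywhere, there is nothing to say a small change at that position moves the result. The expectation in this assay is no shift beyond the usual scatter, and most likely the same absent result as compound 2.

Compound 3 is estimated at 60000 nM, expected to lie between 15000 nM and 250000 nM if a number is obtained at all.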

Compound 3, half-maximal inhibitory concentration: "not active" (no number reported)
Compound 3 has no reported number here, and the estimate cannot be compared.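

Compound 2 and compound 3 both come back from this assay as "not active" (no number reported), so no step can be read between them. On these data alone, whether replacing cyclopropylamino with 4-hydroxypiperidin-1-yl changes the result in any way stays open, since neither compound has a number to compare. No evidence shown here bears on this shared result.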